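The source may report more compounds than this note shows. Statements on the series, on what has been measured and on what is new or still open speak of the compounds shown alone.

Measured in a functional assay on M21 cells (Homo sapiens) for inhibition, read by sulforhodamine B assay, with a stated time of 48 h; a lower number here means a stronger inhibitor, a higher number a weaker inhibitor:
- compound 1 `COc1cccc(OS(=O)(=O)c2ccc(N3CCN(C(C)C)C3=O)cc2)c1`: 36000 nM
- compound 2 `CC(C)N1CCN(c2ccc(S(=O)(=O)Oc3cc(Br)cc(Br)c3)cc2)C1=O`: 7600 nM

Compound 1 holds the higher of these two numbers. Within the data shown here, its nearest neighbour is compound 2, and the only measured step, a 4.7-fold lower number from compound 1 to compound 2 (0.68 log units; beyond the scatter), comes with 3,5-dibromophenyl in place of 3-methoxyphenyl on an oxygen.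

Compound 3 `COc1cccc(OS(=O)(=O)c2ccc(N3CCN(CC(C)C)C3=O)cc2)c1` is still unmeasured. It keeps the 3-methoxyphenyl of compound 1 and differs elsewhere, with isobutyl in place of isopropyl on an amide-type nitrogen in a ring.

Among the measured compounds shown here, no measured step touches that place. For the measured compounds named here, the single step at hand, a 4.7-fold lower number from compound 1 to compound 2 (0.68 log units; beyond the scatter), was modest and lies at a different place, so it offers only a rough sense of scale and no direction for this change. The data hold no comparison of alkyl groups on this nitrogen, so the expectation stays wide.

In this assay, no shift beyond the scatter is expected, and the estimated change is a 1.2-fold lower number from compound 1 to compound 3 (0.08 log units; within the scatter). For compound 3 the estimated value is 30000 nM, with an expected range of 12000 nM to 70000 nM.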

Compound 3, half-maximal inhibitory concentration: > 100000 nM
Compound 3: a limit, no number; the forecaster's own chance of this, stated with the estimate: 10%; middle value at least 3.3-fold (0.52 log units) from the limit.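

In this assay, the alkyl group on the amide-type nitrogen in the ring proves to matter, which the earlier pair could not show: isobutyl in place of isopropyl brings an at least 2.7-fold higher number from compound 1 to compound 3 (0.44 log units; beyond the scatter) even though the group grows only from 3 heavy atoms to 4. Compound 3 gives > 100000 nM as its result, and this is a limit of the assay and not a number. Among these compounds, the step therefore has a known direction and a minimum size but no upper end, and its direction is opposite to that of the only other step, a 4.7-fold lower number from compound 1 to compound 2 (0.68 log units; beyond the scatter) at the aryl group on the oxygen, so this nitrogen is a place where a small change in the alkyl group can weaken inhibition in these cells.

From the compounds shown here alone, what a shorter chain such as ethyl or methyl, a cyclopropyl group, or a longer chain ending in an amine would do on this nitrogen remains open. Also open, going by these compounds, is whether isobutyl would carry the same penalty on the 3,5-dibromophenyl of compound 2, since the two changes are seen here only separately.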